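Working notes: hydroxy on the phenyl of compound 1

A few compounds are considered here, and "the series" means these few. Any claim that something is new, unique, unknown or untested is made for them only; others in the source may bear on it.

For the measured compounds named here, in a physicochemical assay for lipophilicity, measured as octanol-water partition (on this read-out higher numbers stand for higher lipophilicity and lower numbers for lower lipophilicity), compound 1 (`C/C(=N\NC(=O)COc1cccc2ccccc12)c1ccccc1`) gives 3.65 and holds the higher of the two numbers so far. Compound 2 (`COc1cc(/C=N/NC(=O)COc2cccc3ccccc23)cc(OC)c1OC`) gives 3.26 on the same read-out, a lower number, and the gap between the two lies beyond the usual scatter. These two compounds differ in more than one place, so their gap says nothing about any single change.

The next compound to be measured is compound 3 (`C/C(=N\NC(=O)COc1cccc2ccccc12)c1ccccc1O`). It carries hydroxy in place of hydrogen on an aromatic carbon, ortho to a large group (hydroxy in place of hydrogen on an aromatic carbon), so the phenyl of compound 1 becomes 2-hydroxyphenyl. Going by the values given here, no measured pair isolates this change, and the expectation rests on the structural change alone.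

A modest fall in this assay is expected, and the estimated step of a number 0.35 log units lower from compound 1 to compound 3 (beyond the scatter) lies only slightly beyond the scatter, with no-change outcomes still plausible. The estimated value for compound 3 is 3.3 with an expected range from 2.9 to 3.7 as the working figure.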

Compound 3, partition coefficient: 3.08
The estimate for compound 3 lay 0.22 log units above the measured number; low and high end bracket the measured number.
By their numbers in this assay, from the lowest: compounds 3 and 2 (each within the scatter of the next); then compound 1.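

In this assay, hydroxy in place of hydrogen on an aromatic carbon, ortho to a large group, gives a number 0.57 log units lower from compound 1 to compound 3 (beyond the scatter), and the rest of the structure stays unchanged. For the compounds shown here, this is the first change that can be read at a single place: the gap between compound 1 and compound 2 could not be assigned to any one difference, whereas here the entry of one oxygen atom as hydroxy, turning phenyl into 2-hydroxyphenyl, is enough to move the number beyond the scatter. No measurement at hand bears on why the number falls at this position.

As far as these compounds go, with one pair, it remains open whether the size of this step belongs to hydroxy itself or would also appear with another group at the same place, such as methoxy or an amine. From the compounds shown here alone, it also remains open whether the same replacement would give a step of similar size on a different member of the series, since the step has so far been read only on the core of compound 1.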